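A Thiophene Ring Replaces the Tolyl Group

A few compounds are considered here, and "the series" means these few. Any claim that something is new, unique, unknown or untested is made for them only; others in the source may bear on it.

Of the compounds shown here, three that share a core have been measured so far. Compound 1 `CCOc1nc(-c2nc3ccccc3n2C)cc(-c2ccccc2)c1C#N` gives 364000 nM in a functional assay on aorta (Rattus norvegicus, strain Wister); a lower number here means a stronger inhibitor, a higher number a weaker inhibitor. Compound 2 `CCOc1nc(-c2nc3ccccc3n2C)cc(-c2ccc(Cl)cc2Cl)c1C#N` gives 305000 nM, and compound 3 `CCOc1nc(-c2nc3ccccc3n2C)cc(-c2ccc(C)cc2)c1C#N` gives 400000 nM. Compound 3 holds the highest number of the three, but the step of a 1.1-fold higher number from compound 1 to compound 3 (0.04 log units; within the scatter) and the step of a 1.3-fold higher number from compound 2 to compound 3 (0.12 log units; within the scatter) both stay within the scatter, as does the step of a 1.2-fold lower number from compound 1 to compound 2 (0.08 log units; within the scatter), so no order among them can be claimed.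

Compound 4 `CCOc1nc(-c2nc3ccccc3n2C)cc(-c2cccs2)c1C#N` differs from compound 3 in one place: thiophen-2-yl in place of 4-methylphenyl on an aromatic carbon. All three measured steps concern a change of the aryl group on that same aromatic carbon of the shared core, and none of them moved the number beyond the scatter, whether a phenyl became a 2,4-dichlorophenyl or a 4-methylphenyl. Within the data shown here, a thiophen-2-yl ring at that position is a new kind of change, and no measured pair here separates a five-membered heteroaromatic ring from a six-membered carbon ring. The step of a 1.1-fold lower number from compound 3 to compound 4 (0.02 log units; within the scatter) is therefore expected to be small, with no direction beyond the scatter. Compound 4 is estimated at 380000 nM, within a range from 150000 nM to 900000 nM.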

Compound 4, half-maximal inhibitory concentration: 249000 nM
Estimate against measurement, compound 4: 1.5-fold (0.18 log units) above; the range from low to high includes it.
By their numbers in this assay, from the lowest: compounds 4, 2, 1 and 3 (each within the scatter of the next).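

Up to this point, the aromatic carbon opposite the ring nitrogen had carried only six-membered rings of carbon, and compound 4 shows that a five-membered aromatic ring with 1 hetero atom can stand there without a step beyond the scatter in this assay. The step of a 1.6-fold lower number from compound 3 to compound 4 (0.21 log units; within the scatter) and the step of a 1.2-fold lower number from compound 2 to compound 4 (0.09 log units; within the scatter) and the step of a 1.5-fold lower number from compound 1 to compound 4 (0.16 log units; within the scatter) all stay within it, so thiophen-2-yl cannot be separated from 4-methylphenyl, 2,4-dichlorophenyl or phenyl, and the four compounds cannot be put in any order. The change of ring size, the sulfur atom and the hydrogen-bond acceptor that enter with thiophen-2-yl therefore come with no readable difference in this series, and no measurement at hand bears on this result.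

The compounds shown all carry an aromatic ring at this carbon, so it remains open whether an amine, a carboxylic acid or a longer alkyl chain there would give a step beyond the scatter. Also open is how the number would respond to a change of the ethoxy group or the cyano group, since every step shown concerns the aryl position alone.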